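A few compounds are considered here, and "the series" means these few. Any claim that something is new, unique, unknown or untested is made for them only; others in the source may bear on it.

Of the compounds shown here, three sharing one core have been tested in a functional assay on HCT-15 cells (Homo sapiens) for inhibition, read by sulforhodamine B assay, with a stated time of 48 h, tested at 50 uM; on this read-out lower numbers stand for less inhibition of growth and higher numbers for more inhibition of growth at the one concentration tested. Compound 1 `O=C(Nc1cn2cc(I)ccc2n1)C(F)(F)F` gives 56.3% and compound 2 `O=C(c1ccc(C(F)(F)F)c(F)c1)c1ccc2nc(NC(=O)C(F)(F)F)cn2c1` gives 59.2%, two values within the usual scatter of each other. Compound 3 `Cc1ccc(F)c(C(=O)c2ccc3nc(NC(=O)C(F)(F)F)cn3c2)c1` reaches 91.2%, the highest of the three and beyond the scatter from both of the others. Compound 4 `Cc1ccc(C(=O)c2ccc3nc(NC(=O)C(F)(F)F)cn3c2)cc1F` has the same atoms as compound 3, joined differently: 3-fluoro-4-methylphenyl in place of 2-fluoro-5-methylphenyl on a carbonyl carbon. Here 3-fluoro-4-methylphenyl takes the place of 2-fluoro-5-methylphenyl on a carbonyl carbon. Among the measured compounds shown here, no pair of measured compounds shows this swap, so any forecast is uncertain. Compound 2, with another group on that carbonyl carbon, gives 59.2% against compound 3 at 91.2%, so the group in this place can go with a large difference. Starting from the top of the range seen so far, the expected change is a fall beyond the scatter, a number 17.2 percentage points lower from compound 3 to compound 4 (beyond the scatter). For compound 4 the estimated value is 74%, with an expected range of 50% to 93%.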

Compound 4, percent growth inhibition at one concentration: 65.5%
Compound 4: the middle estimate sits 8.5 percentage points above what was measured, and the stated range covers the measured number.
By their numbers in this assay, from the lowest: compounds 1, 2 and 4 (each within the scatter of the next); then compound 3.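

In this assay, rearranging the same atoms is enough to matter: 3-fluoro-4-methylphenyl in place of 2-fluoro-5-methylphenyl on a carbonyl carbon gives a number 25.7 percentage points lower from compound 3 to compound 4 (beyond the scatter), so this position responds to how the fluorine and methyl are arranged and not only to which atoms are present. Methyl in place of trifluoromethyl on an aromatic carbon, by contrast, gives a number 6.3 percentage points higher from compound 2 to compound 4 (within the scatter), so this pair shows no readable effect of that change. Nothing measured here explains the difference between the two arrangements.

It remains open whether the fluorine or the methyl accounts for the gap, since no phenyl carrying only one of them is among the compounds shown. On these data alone, how a methoxy, an amine or a carboxylic acid on that phenyl would read also remains open.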